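The source may hold more compounds than are shown below. What is called first, only, known or untested is meant among the compounds shown, and "the series" means these compounds.

Measured in a functional assay on HeLa cells (Homo sapiens) for cytotoxicity, read by MTT assay, with a stated time of 48 h; on this read-out lower numbers stand for stronger inhibition and higher numbers for weaker inhibition:
- compound 1 `COc1cc([C@@H]2C[C@]2(CO)C(=O)Nc2ccccc2Cl)cc(OC)c1OC`: 8100 nM
- compound 2 `CCOC(=O)C1(C(=O)Nc2ccccc2Cl)CC1c1cc(OC)c(OC)c(OC)c1`: 22100 nM; 76400 nM (2 entries)
- compound 3 `CCOC(=O)[C@]1(C(=O)NCc2ccc(C)cc2)C[C@H]1c1cc(OC)c(OC)c(OC)c1`: 28500 nM

Of the two compounds with a single number, compound 3 has the higher one, so it is the weaker inhibitor here. Compound 1 lies below it by more than the usual scatter. Compound 2 has no single number, only (the several entries of compound 2 in this assay, 22100 nM; 76400 nM (2 entries)).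

Compound 4 `CCOC(=O)[C@]1(C(=O)Nc2ccccc2Cl)C[C@H]1c1cc(OC)c(OC)c(OC)c1` differs from compound 3 in one place: 2-chlorophenyl in place of 4-methylbenzyl on an amide-type nitrogen. In words, 2-chlorophenyl takes the place of 4-methylbenzyl on an amide-type nitrogen. Within the data shown here, no measured pair shows this change alone, so any forecast is uncertain.

The best guide is compound 2, which also carries 2-chlorophenyl and gives 22100 nM; 76400 nM (2 entries) in this assay. Those entries span a range that includes the number for compound 3. No step beyond the scatter is therefore expected, in either direction. The estimated change is a 1.1-fold lower number from compound 3 to compound 4 (0.06 log units; within the scatter). For compound 4 the expected value is 25000 nM, with an estimated range of 10000 nM to 70000 nM.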

Compound 4, half-maximal inhibitory concentration: 42400 nM
Beside the measured number, compound 4's estimate is 1.7-fold (0.23 log units) below it; low and high end bracket the measured number.
By their numbers in this assay, from the lowest: compound 1; then compounds 3 and 4 (each within the scatter of the next).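

In this assay, the exchange on the amide-type nitrogen gives a 1.5-fold higher number from compound 3 to compound 4 (0.17 log units; within the scatter), so this assay does not separate 2-chlorophenyl from 4-methylbenzyl at this position. The change on the saturated ring carbon, ethoxycarbonyl in place of hydroxymethyl, gives a 5.2-fold higher number from compound 1 to compound 4 (0.72 log units; beyond the scatter), a modest step but one beyond the scatter, so among these compounds the group on that carbon shows a clearer difference than the group on the nitrogen. Compound 2 sharpens neither reading, as its numbers spread widely: the several entries of compound 2 in this assay, 22100 nM; 76400 nM (2 entries).

Going by these compounds, it remains open whether hydroxymethyl would also give a lower number with 4-methylbenzyl on the nitrogen, and what a carboxylic acid or an amine on that ring carbon would give. Comparing compound 2 with compound 4 is further limited by one point: the fact that one of compounds 2 and 4 is drawn with a defined configuration and the other without, at the place where they differ.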